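A few compounds are considered here, and "the series" means these few. Any claim that something is new, unique, unknown or untested is made for them only; others in the source may bear on it.

Compound 1 `CCOc1ccc2oc(/C=C/[S+](C)[O-])cc(=O)c2c1`: 1500 nM in a functional assay on A549 cells (Homo sapiens) for cytotoxicity, with a stated time of 48 h; a higher number here means a weaker inhibitor, a lower number a stronger inhibitor
Compound 2 `CCCCOc1ccc2oc(/C=C/[S+](C)[O-])cc(=O)c2c1`: 1400 nM in this assay
Compound 3 `CCCOc1ccc2oc(/C=C/[S+](C)[O-])cc(=O)c2c1`: 1100 nM in this assay

The three measured compounds share one core and differ only in the alkyl chain on the aromatic oxygen. Their numbers in this assay sit close together: the step of a 1.1-fold higher number from compound 2 to compound 1 (0.03 log units; within the scatter) and the step of a 1.4-fold lower number from compound 1 to compound 3 (0.13 log units; within the scatter) both stay within the scatter, as does a 1.3-fold lower number from compound 2 to compound 3 (0.10 log units; within the scatter). Compound 4 `COc1ccc2oc(/C=C/[S+](C)[O-])cc(=O)c2c1` is not yet measured. It differs from compound 3 by hydrogen in place of ethyl on a saturated chain carbon bound to an oxygen on an aromatic ring. The same kind of change is already on record as hydrogen in place of ethyl on a saturated chain carbon, two bonds along the chain from an oxygen on an aromatic ring, which gave a 1.1-fold higher number from compound 2 to compound 1 (0.03 log units; within the scatter); there the place is two bonds along the chain from the aromatic oxygen, whereas in compound 4 the place is bound to that oxygen. The core difference between compound 3 and compound 2 is hydrogen in place of methyl on a saturated chain carbon, three bonds along the chain from an oxygen on an aromatic ring. Since shortening the chain has so far not moved the number beyond the scatter, compound 4 is expected to show a step of a 1.4-fold higher number from compound 3 to compound 4 (0.13 log units; within the scatter), resting on a 1.1-fold higher number from compound 2 to compound 1 (0.03 log units; within the scatter). Compound 4 is therefore estimated at 1500 nM, between 700 nM and 3500 nM.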

Compound 4, half-maximal inhibitory concentration: 1600 nM
Estimate against measurement, compound 4: 1.1-fold (0.03 log units) below, and the stated range covers the measured number.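

In this assay, compound 4 adds three steps to the series: a 1.5-fold higher number from compound 3 to compound 4 (0.16 log units; within the scatter), a 1.1-fold higher number from compound 2 to compound 4 (0.06 log units; within the scatter) and a 1.1-fold higher number from compound 1 to compound 4 (0.03 log units; within the scatter), and all three lie within the scatter. Replacing ethyl with hydrogen shows no difference between the two cores on which it can be compared: the same change on two cores in this assay, a 1.1-fold higher number (0.03 log units; within the scatter) from compound 2 to compound 1 and a 1.5-fold higher number (0.16 log units; within the scatter) from compound 3 to compound 4, 1.4-fold (0.13 log units) apart, within the scatter of two such steps Replacing methyl with hydrogen also shows no such difference, but these small steps show only that both changes stay within the scatter on these cores, not that a change with a larger effect would carry from one core to another in the same way: the same change on two cores in this assay, a 1.3-fold lower number (0.10 log units; within the scatter) from compound 2 to compound 3 and a 1.1-fold higher number (0.03 log units; within the scatter) from compound 1 to compound 4, 1.4-fold (0.13 log units) apart, within the scatter of two such steps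

The compounds shown leave open whether a longer chain, a branched chain or a hydroxyl in place of the alkoxy group would move the number beyond the scatter. They also leave open whether an amine or a carboxylic acid at the end of the chain would do so.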